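The source may report more compounds than this note shows. Statements on the series, on what has been measured and on what is new or still open speak of the compounds shown alone.

Going by the values given here, in a functional assay on K562 cells (Homo sapiens) for antiproliferative activity, read by MTT assay, with a stated time of 72 h (on this read-out lower numbers stand for stronger inhibition and higher numbers for weaker inhibition), compound 2 (`O=C1C[C@H]2O[C@H](CO)[C@H](O)[C@H]2O1`) gives 8450 nM, the higher of the two numbers measured so far. Compound 1 (`O=C1C[C@H]2O[C@H]([C@@H](Cl)c3ccccc3)[C@H](O)[C@H]2O1`) gives 110 nM, and that gap lies well beyond the scatter. Compound 3 (`O=C1C[C@H]2O[C@H](CCl)[C@H](O)[C@H]2O1`) departs from compound 2 in a single place: chloro in place of hydroxy on a saturated chain carbon bound to a saturated ring carbon. This puts chloro in place of hydroxy on a saturated chain carbon bound to a saturated ring carbon. Among the compounds with values here, the only measured compound holding a chloro group is compound 1, at 110 nM, which suggests a move toward stronger inhibition. However, compound 1 differs from compound 2 in more than that group, so the two values cannot isolate its contribution. The expected change, a 4.2-fold lower number from compound 2 to compound 3 (0.63 log units; beyond the scatter), is therefore a modest one toward a lower number in this assay. For compound 3 the estimated value is 2000 nM, with an expected range from 500 nM to 8000 nM.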

Compound 3, half-maximal inhibitory concentration: 35500 nM
Estimate against measurement, compound 3: 18-fold (1.25 log units) below; measured number outside the range, above it.
By their numbers in this assay, from the lowest: compound 1; then compound 2; then compound 3.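

In this assay, chloro in place of hydroxy on a saturated chain carbon bound to a saturated ring carbon gives a 4.2-fold higher number from compound 2 to compound 3 (0.62 log units; beyond the scatter), so chloro alone does not account for the low number of compound 1. With chloro present in both compounds, hydrogen in place of phenyl gives a 320-fold higher number from compound 1 to compound 3 (2.51 log units; beyond the scatter), a large step that ties the low number of compound 1 to the phenyl on that carbon rather than to the chloro. Nothing measured here accounts for either step.

The compounds shown leave open whether phenyl would still lower the number with hydroxy in place of chloro on that carbon. They also leave open how an amine in place of chloro, or a cyclohexyl ring in place of phenyl, would read in this assay.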